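The source may hold more compounds than are shown below. What is called first, only, known or untested is meant among the compounds shown, and "the series" means these compounds.

Measured so far:
compound 1, `O=C(CCc1ccc(O)cc1)C[C@@H](O)CCc1ccccc1`, 75700 nM
compound 2, `COc1cc(CCC(=O)C[C@@H](O)CCc2ccc(O)cc2)ccc1O`, 37500 nM

In a functional assay on RAW264.7 cells (Mus musculus) for inhibition, read by spectrophotometry and Griess assay, with a stated time of 24 h (a higher number here means a weaker inhibitor, a lower number a stronger inhibitor), compound 2 gives the lower of the two numbers; compound 1 stands higher, with a gap beyond the usual scatter. Compound 3, `O=C(CCc1ccc(O)cc1)C[C@@H](O)CCc1ccc(O)cc1`, is not yet measured. It differs from compound 2 by hydrogen in place of methoxy on an aromatic carbon. Within the data shown here, no pair of measured compounds isolates this change, and compound 1 differs from compound 2 in more than one place, so the comparison of their values cannot be read as this step alone. The step is expected to be small, a slight rise in number at most, within the scatter: a 1.3-fold higher number from compound 2 to compound 3 (0.12 log units; within the scatter). Compound 3 is expected at 50000 nM, with a range from 20000 nM to 120000 nM.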

Compound 3, half-maximal inhibitory concentration: 46400 nM
The estimate for compound 3 lay 1.1-fold (0.03 log units) above the measured number; the range from low to high includes it.
By their numbers in this assay, from the lowest: compounds 2, 3 and 1 (each within the scatter of the next, the first and the last beyond it).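

In this assay, hydrogen in place of methoxy on the aromatic carbon ortho to a hydroxy group gives a 1.2-fold higher number from compound 2 to compound 3 (0.09 log units; within the scatter) and stays within the scatter, so the methoxy is not needed at this position for the activity seen here. The second single change, hydroxy in place of hydrogen on an aromatic carbon, gives a 1.6-fold lower number from compound 1 to compound 3 (0.21 log units; within the scatter) and also stays within the scatter. No measurement on hand explains the size of either step.

Going by these compounds, whether an amine, a carboxylic acid or a chlorine at this aromatic carbon would move the number beyond the scatter remains open. So does the effect of a longer chain in place of the methoxy.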